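A few compounds are considered here, and "the series" means these few. Any claim that something is new, unique, unknown or untested is made for them only; others in the source may bear on it.

In a functional assay (aorta) with Rattus norvegicus as the target (a lower number here means a stronger inhibitor, a higher number a weaker inhibitor), three compounds sharing one core have been measured, and they differ only in the amino group on the saturated chain. Compound 1 `CC(C)c1cn2ccccc2c1S(=O)(=O)c1ccc(OCCCN2CCC(c3ccccc3)CC2)cc1`, with 4-phenylpiperidin-1-yl, gives 80.9 nM. Compound 2 `CC(C)c1cn2ccccc2c1S(=O)(=O)c1ccc(OCCCN(C)C)cc1`, with dimethylamino, gives 390 nM. Compound 3 `CCCCN(CCCC)CCCOc1ccc(S(=O)(=O)c2c(C(C)C)cn3ccccc23)cc1`, with dibutylamino, gives 21.6 nM, the lowest number of the three and beyond the scatter of both others.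

Compound 4 `CCCCN(CCCC)CCCOc1ccc(S(=O)(=O)c2c(C)cn3ccccc23)cc1` keeps the dibutylamino chain of compound 3 and changes a different place: methyl in place of isopropyl on an aromatic carbon.

Within the data shown here, none of the measured steps touches this position, so the data offer no direct precedent for its size or direction. The steps at the amino group bear on it only indirectly. They are a 4.8-fold higher number from compound 1 to compound 2 (0.68 log units; beyond the scatter), a 3.7-fold lower number from compound 1 to compound 3 (0.57 log units; beyond the scatter) and an 18-fold lower number from compound 2 to compound 3 (1.26 log units; beyond the scatter), and they show that one change on this core can move the number by a modest to a large amount. As a judgement rather than a measured trend, a modest rise is expected, with no change beyond the scatter also possible: a 2.8-fold higher number from compound 3 to compound 4 (0.44 log units; beyond the scatter) is the estimated step. For compound 4 the expected value is 60 nM, with an estimated range from 15 nM to 240 nM.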

Compound 4, half-maximal inhibitory concentration: 162 nM
For compound 4 the middle estimate is 2.7-fold (0.43 log units) below the measured one; measured number inside the range.
By their numbers in this assay, from the lowest: compound 3; then compounds 1 and 4 (each within the scatter of the next); then compound 2.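

In this assay the step at this position, a 7.5-fold higher number from compound 3 to compound 4 (0.88 log units; beyond the scatter), shows that this aromatic carbon of the five-membered ring matters to the number, something the steps at the amino group could not show. With the dibutylamino chain held fixed, methyl in place of isopropyl is enough on its own to carry the number beyond the scatter, and the rise goes with the smaller group: isopropyl has 3 heavy atoms and methyl has 1, while neither group has a ring, a hydrogen-bond donor or acceptor, or a net charge. The compounds come with no measurement that explains why the number rises at this position.

As far as these compounds go, with only isopropyl and methyl at this place, it remains open whether the number follows the size of the group in any regular way, and hydrogen, ethyl, cyclopropyl or tert-butyl there would be needed to tell. From the compounds shown here alone, it is also open whether methyl in place of isopropyl moves the number the same way on the dimethylamino or 4-phenylpiperidin-1-yl chains, since this step has been read on the dibutylamino chain alone.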